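Swapping One Aromatic Ring on the Shared Core

The source may hold more compounds than are shown below. What is called first, only, known or untested is meant among the compounds shown, and "the series" means these compounds.

Compound 1 `CC(C)(C)c1ccc(-n2nc(-c3ccc(C(F)(F)F)cc3O)nc2-c2ccccc2O)cc1` was tested in a functional assay on PC-12 cells (Rattus norvegicus) for cytotoxicity, read by MTT assay, with stated times of 2 h and 24 h, tested at 1 uM (on this read-out lower numbers stand for a weaker effect and higher numbers for a stronger effect at the one concentration tested), where compound 1 gives 67.3%. In this assay compound 2 `Oc1cc(C(F)(F)F)ccc1-c1nc(-c2ccccc2O)n(-c2ccc(Cl)cc2)n1` gives 68% and compound 3 `Oc1cc(C(F)(F)F)ccc1-c1nc(-c2ccccc2O)n(-c2ccccc2Cl)n1` gives 70.1%. Compound 1 sits at the low end of these three numbers, though no two of them are set apart beyond the scatter. Compound 4 `Oc1cc(C(F)(F)F)ccc1-c1nc(-c2ccccc2O)n(-c2ccc(F)cc2F)n1` differs from compound 1 in one place: 2,4-difluorophenyl in place of 4-(tert-butyl)phenyl on an aromatic nitrogen. Two measured steps also alter the ring on that aromatic nitrogen, a number 0.7 percentage points higher from compound 1 to compound 2 (within the scatter) and a number 2.8 percentage points higher from compound 1 to compound 3 (within the scatter), and the step of a number 2.1 percentage points higher from compound 2 to compound 3 (within the scatter) is likewise small. With all of these within the scatter, compound 4 is expected to show no step beyond it, an expected a number 1.7 percentage points higher from compound 1 to compound 4 (within the scatter). The estimate for compound 4 is 69%, within 58% to 80%.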

Compound 4, a percentage reported as activity, at one concentration (the size of the read-out at that concentration, not a potency): 65.9%
Compound 4: middle estimate off by 3.1 percentage points, on the high side, and the stated range covers the measured number.
By their numbers in this assay, from the lowest: compounds 4, 1, 2 and 3 (each within the scatter of the next).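

In this assay the 2,4-difluorophenyl ring adds three steps (a number 1.4 percentage points lower from compound 1 to compound 4 (within the scatter) and a number 2.1 percentage points lower from compound 2 to compound 4 (within the scatter) and a number 4.2 percentage points lower from compound 3 to compound 4 (within the scatter)). A phenyl ring carrying two fluorines on the aromatic nitrogen therefore stays within the scatter of all three earlier rings, so none of these four compounds stands apart. Nothing available explains this flat result.

Every ring shown at this position is a phenyl ring bearing chloro, fluoro or tert-butyl. On these data alone, whether an amine, a carboxylic acid or a longer chain there would give a step beyond the scatter remains open.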